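The source may report more compounds than this note shows. Statements on the series, on what has been measured and on what is new or still open speak of the compounds shown alone.

Working notes on the series. The shared core carries an acid-bearing biphenyl joined through a two-carbon chain to an imidazole, and the compounds differ only in the group hanging from that imidazole. Compound 1 `O=C(O)c1ccccc1-c1ccc(CCc2ncc(C3CCCCC3)[nH]2)cc1` carries a cyclohexyl there, and in an in vitro functional assay on cells for agonist activity at Bombesin receptor subtype-3 (Homo sapiens), read by luminescence and calcium flux (a lower number here means that less compound is needed, a higher number that more compound is needed for the effect), compound 1 gives 375 nM. Compound 2 `Cc1ccccc1Cc1cnc(CCc2ccc(-c3ccccc3C(=O)O)cc2)[nH]1` carries a 2-methylbenzyl in the same place, and in this assay compound 2 gives 127 nM. Going by the values given here, the single measured step, a 3.0-fold lower number from compound 1 to compound 2 (0.47 log units; beyond the scatter), is the only comparison available, and on it compound 2 stands at the lower of the two numbers.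

Compound 3 `O=C(O)c1ccccc1-c1ccc(CCc2ncc(CC3CCCC3)[nH]2)cc1` is the next variation: cyclopentyl in place of 2-methylphenyl on a saturated chain carbon bound to an aromatic carbon. This returns to a saturated carbon ring, as in compound 1, but one bond further out and with a five-membered rather than six-membered ring. Among the compounds with values here, the step of a 3.0-fold lower number from compound 1 to compound 2 (0.47 log units; beyond the scatter) is the only guide, and it suggests the saturated ring sits at the higher number. The expectation for compound 3 is therefore a number higher than compound 2 in this assay, of the order of a 2.4-fold higher number from compound 2 to compound 3 (0.37 log units; beyond the scatter), with a wide range since no saturated ring bound through a chain carbon has been measured. Compound 3 is estimated at 300 nM, between 100 nM and 900 nM.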

Compound 3, half-maximal effective concentration: 133 nM
Estimate against measurement, compound 3: 2.3-fold (0.35 log units) above; the measured number falls inside the stated range.
By their numbers in this assay, from the lowest: compounds 2 and 3 (each within the scatter of the next); then compound 1.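

In this assay, the 2-methylphenyl and the cyclopentyl on the saturated chain carbon cannot be told apart, a 1.0-fold higher number from compound 2 to compound 3 (0.02 log units; within the scatter), so within these two compounds an aromatic ring at this place is not required for the lower number. With cyclopentylmethyl in place of cyclohexyl there is a 2.8-fold lower number from compound 1 to compound 3 (0.45 log units; beyond the scatter), a step of similar size to a 3.0-fold lower number from compound 1 to compound 2 (0.47 log units; beyond the scatter); the two groups carried on a saturated chain carbon therefore sit together, and compound 1, with its ring directly on the aromatic carbon, stands apart, although this step changes ring size and the chain carbon at once and cannot assign the shift to either. No supporting data bear on why these groups read as they do.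

Still open, from the compounds shown here alone, is whether cyclohexylmethyl would read with compound 3 or with compound 1, which would separate the contribution of ring size from that of the chain carbon. Also open, going by these compounds, is how far this place tolerates anything other than carbon-only groups, such as an amine or a carboxylic acid on the ring, or a longer chain leading to it.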